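The source may report more compounds than this note shows. Statements on the series, on what has been measured and on what is new or still open speak of the compounds shown alone.

Measured compounds:
compound 1 `COc1ncnc2c1c(-c1ccsc1)cn2[C@@H]1O[C@H](CO)[C@@H](O)[C@H]1O` — 120 nM
compound 2 `CNc1ncnc2c1c(-c1ccsc1)cn2[C@@H]1O[C@H](CO)[C@@H](O)[C@H]1O` — > 20000 nM
compound 3 `CNc1ncnc2c1c(-c1ccco1)cn2[C@@H]1O[C@H](CO)[C@@H](O)[C@H]1O` — 230 nM

In a functional assay on HCT-116 cells (Homo sapiens), read by MTT assay, with a stated time of 72 h (a higher number here means a weaker inhibitor, a lower number a stronger inhibitor), compound 1 gives 120 nM. Compound 2 reaches only a limit of the assay, > 20000 nM, which is the limit of > 20000 nM in this assay, at which 1 of the 3 values shown sits. Compound 3 gives 230 nM.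

Two changes were made. From compound 2 to compound 1 the change is methoxy in place of methylamino on an aromatic carbon, and it brings an at least 160-fold lower number from compound 2 to compound 1 (2.22 log units; beyond the scatter). From compound 2 to compound 3 the cores differ by furan-2-yl in place of thiophen-3-yl on an aromatic carbon, which brings an at least 86-fold lower number from compound 2 to compound 3 (1.93 log units; beyond the scatter). Compound 3 stands with its number in this assay close to compound 1, the two lying within the scatter of each other.

Compound 4 `COc1ncnc2c1c(-c1ccco1)cn2[C@@H]1O[C@H](CO)[C@@H](O)[C@H]1O` has not been measured in this assay. It differs from compound 3 by methoxy in place of methylamino on an aromatic carbon, the same change as from compound 2 to compound 1, at the same place. The earlier step began from a limit of the assay for compound 2, so its true size is not known. Compound 3 already sits at 230 nM, close to compound 1, which leaves less room for a change of the same magnitude. Compound 4 is therefore expected to show a smaller step, a 2.6-fold lower number from compound 3 to compound 4 (0.41 log units; beyond the scatter), and an estimated value of 90 nM, most likely between 25 nM and 400 nM.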

Compound 4, half-maximal inhibitory concentration: 40 nM
For compound 4 the middle estimate is 2.3-fold (0.35 log units) above the measured one; measured number inside the range.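

In this assay, methoxy in place of methylamino on the core carrying furan-2-yl gives a 5.8-fold lower number from compound 3 to compound 4 (0.76 log units; beyond the scatter), the same direction as on the core carrying thiophen-3-yl, but the size does not carry over: the same change on two cores in this assay, an at least 160-fold lower number (2.22 log units; beyond the scatter) from compound 2 to compound 1 and a 5.8-fold lower number (0.76 log units; beyond the scatter) from compound 3 to compound 4, at least 28-fold (1.46 log units) apart, beyond the scatter of two such steps Furan-2-yl in place of thiophen-3-yl, with methoxy already in place, gives a 3.0-fold lower number from compound 1 to compound 4 (0.48 log units; beyond the scatter), so this change also keeps its direction but not its size: the same change on two cores in this assay, an at least 86-fold lower number (1.93 log units; beyond the scatter) from compound 2 to compound 3 and a 3.0-fold lower number (0.48 log units; beyond the scatter) from compound 1 to compound 4, at least 28-fold (1.46 log units) apart, beyond the scatter of two such steps Across these four compounds, each change lowers the number on both cores, yet neither has a step size that can be carried to the other core, and the larger step of each pair has no known true size, since it starts from a value that is only a limit for compound 2: the limit of > 20000 nM in this assay, at which 1 of the 4 values shown sits.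

What the compounds shown leave open is whether a primary amine, dimethylamino or ethoxy at the same aromatic carbon would follow methoxy or methylamino. They also leave open whether the same dependence on the core would hold for a longer chain there.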